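The source may report more compounds than this note shows. Statements on the series, on what has been measured and on what is new or still open speak of the compounds shown alone.

Compound 3, `N[C@]1(C(=O)O)[C@H]2[C@@H](C[C@H]1OCc1ccc(F)c(F)c1)[C@]2(F)C(=O)O`, has the lowest number among the three measured compounds in an assay on CHO cells for binding affinity to metabotropic glutamate receptor 2 (Rattus norvegicus) (a higher number here means a weaker inhibitor, a lower number a stronger inhibitor), where compound 3 gives 2.27 nM. Its nearest neighbour is compound 1, `N#Cc1cccc(CO[C@@H]2C[C@@H]3[C@H]([C@]2(N)C(=O)O)[C@@]3(F)C(=O)O)c1`, and the step of a 1.3-fold lower number from compound 1 to compound 3 (0.11 log units; within the scatter) lies within the scatter, so the two cannot be ranked against each other. The furthest is compound 2, `Nc1cccc(CO[C@@H]2C[C@@H]3[C@H]([C@]2(N)C(=O)O)[C@@]3(F)C(=O)O)c1`, for which compound 2 gives 15.4 nM in this assay; the step of a 6.8-fold lower number from compound 2 to compound 3 (0.83 log units; beyond the scatter) is beyond the scatter. For completeness, compound 1 gives 2.94 nM in this assay.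

Compound 4, `N[C@]1(C(=O)O)[C@H]2[C@@H](C[C@H]1OCc1cc(F)cc(F)c1)[C@]2(F)C(=O)O`, differs from compound 3 in one place: 3,5-difluorophenyl in place of 3,4-difluorophenyl on a saturated chain carbon bound to an oxygen on a saturated carbon. The two aryl groups carry the same atoms, only joined differently.

Of the measured steps, the one that bears most directly on this change is the swap of one aryl substitution pattern for another in the step of a 1.3-fold lower number from compound 1 to compound 3 (0.11 log units; within the scatter), which stayed within the scatter. The steps of a 5.2-fold higher number from compound 1 to compound 2 (0.72 log units; beyond the scatter) and a 6.8-fold lower number from compound 2 to compound 3 (0.83 log units; beyond the scatter) each involve an amino group and were modest, but neither speaks to a rearrangement of two fluorine atoms on the ring. For the measured compounds named here, no measured pair compares a 3,4-difluorophenyl with a 3,5-difluorophenyl, so the account expects, on the available evidence, a step of a 1.2-fold higher number from compound 3 to compound 4 (0.09 log units; within the scatter) that stays within the scatter, in no definite direction. For compound 4 the estimated number in this assay is 2.8 nM, with a range from 1 nM to 8 nM.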

Compound 4, inhibition constant: 12.4 nM
For compound 4 the middle estimate is 4.4-fold (0.65 log units) below the measured one; measured number outside the range, above it.
By their numbers in this assay, from the lowest: compounds 3 and 1 (each within the scatter of the next); then compounds 4 and 2 (each within the scatter of the next).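

With the atoms unchanged and only the fluorine pattern altered, 3,5-difluorophenyl in place of 3,4-difluorophenyl gives a 5.5-fold higher number from compound 3 to compound 4 (0.74 log units; beyond the scatter) in this assay, so at this position the arrangement of the two fluorine atoms on the ring can matter on its own, something the earlier exchanges of one substituted ring for another could not isolate. The 3,5-difluorophenyl group also separates from the 3-cyanophenyl group, with a 4.2-fold higher number from compound 1 to compound 4 (0.63 log units; beyond the scatter), while a 1.2-fold lower number from compound 2 to compound 4 (0.09 log units; within the scatter) means that it cannot be ranked against the 3-aminophenyl group. No evidence is available that accounts for the effect of moving the fluorine atoms.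

The compounds shown leave open whether a ring bearing a single fluorine, or chlorine atoms in place of the two fluorine atoms, would fall with compound 3 or with compound 4. They also leave open whether the same sensitivity to the fluorine pattern would persist with a longer chain between the oxygen and the ring.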